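Chloro on the Benzoyl Ring of a Chalcone-Type Enone

A few compounds are considered here, and "the series" means these few. Any claim that something is new, unique, unknown or untested is made for them only; others in the source may bear on it.

Compound 1 `O=C(/C(=C/C1CCCCC1)CCl)c1ccccc1`: 22000 nM
Compound 2 `CC(=O)OC/C(=C\C1CCCCC1)C(=O)c1ccccc1`: 21000 nM
Compound 3 `CC(=O)OC/C(=C\c1ccc(F)cc1)C(=O)c1ccccc1`: 13000 nM

In a functional assay on WiDr cells (Homo sapiens) for inhibition, read by sulforhodamine B assay, with a stated time of 48 h (on this read-out higher numbers stand for weaker inhibition of growth and lower numbers for stronger inhibition of growth), compound 2 gives 21000 nM, which lies within the scatter of both compound 1 and compound 3. The two measured steps, a 1.0-fold lower number from compound 1 to compound 2 (0.02 log units; within the scatter) and a 1.6-fold lower number from compound 2 to compound 3 (0.21 log units; within the scatter), are both small and neither touches the benzoyl ring. Compound 4 `CC(=O)OC/C(=C\C1CCCCC1)C(=O)c1ccc(Cl)cc1` differs from compound 2 by chloro in place of hydrogen on an aromatic carbon. Among the compounds with values here, no measured step bears directly on this position, so for compound 4 the expected change in this assay is a 1.4-fold lower number from compound 2 to compound 4 (0.15 log units; within the scatter), nothing beyond the scatter. Compound 4 is therefore estimated at 15000 nM, with a range from 6000 nM to 40000 nM.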

Compound 4, concentration for 50% growth inhibition: 21000 nM
Beside the measured number, compound 4's estimate is 1.4-fold (0.15 log units) below it; the measured number falls inside the stated range.
By their numbers in this assay, from the lowest: compounds 3, 2, 4 and 1 (each within the scatter of the next).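

In this assay, the change from phenyl to 4-chlorophenyl gives no change at the digits printed from compound 2 to compound 4 (within the scatter). Within the data shown here, this is the first reading at this position on the six-membered aromatic ring, and with the cyclohexyl and acetoxy groups of compound 2 in place, chloro there leaves the number where it was. Nothing measured here bears on why the number stays put. Still open, going by these compounds, is whether an amine or a carboxylic acid at this position would move the number, and whether chloro would do the same alongside the 4-fluorophenyl group of compound 3.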